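A few compounds are considered here, and "the series" means these few. Any claim that something is new, unique, unknown or untested is made for them only; others in the source may bear on it.

Measured so far:
- compound 1 `C#CCCCOc1ccc2cc(C(=O)OC)c(=O)oc2c1` gives 82.4 nM
- compound 2 `C#CCCCOc1ccc2oc(=O)c(C(=O)OC)cc2c1` gives 1440 nM
- compound 3 `C#CCCCCOc1ccc2cc(NC(C)=O)c(=O)oc2c1` gives 41.7 nM

In an assay on cells for inhibition of Amine oxidase [flavin-containing] B (Homo sapiens), read by Amplex Red, with stated times of 30 min and 45 min (a higher number here means a weaker inhibitor, a lower number a stronger inhibitor), compound 2 stands at the highest of the three numbers, and its gap to compound 1 as well as to compound 3 lies beyond the scatter; none of the three pairs differ in one place only, so no single step can be read off among them. Compound 4 `COC(=O)c1cc2cc(OCCc3ccc(Cl)cc3)ccc2oc1=O` is not yet measured. Compared with compound 2 it carries 4-chlorophenyl in place of propargyl on a saturated chain carbon, two bonds along the chain from an oxygen on an aromatic ring; the chain length to the aromatic oxygen is unchanged and the shared core is kept. Going by the values given here, with no matched step in hand, the expectation for compound 4 rests only on the position of compound 2 as the weakest number of the set: a move toward lower numbers of moderate size is expected, a 2.9-fold lower number from compound 2 to compound 4 (0.46 log units; beyond the scatter), though a change within the scatter cannot be excluded. Compound 4 is therefore estimated at 500 nM, with a range from 100 nM to 3000 nM.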

Compound 4, half-maximal inhibitory concentration: 120 nM
Compound 4: the middle estimate sits 4.2-fold (0.62 log units) above what was measured; low and high end bracket the measured number.
By their numbers in this assay, from the lowest: compounds 3, 1 and 4 (each within the scatter of the next, the first and the last beyond it); then compound 2.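

In this assay, 4-chlorophenyl in place of propargyl on a saturated chain carbon, two bonds along the chain from an oxygen on an aromatic ring, gives a 12-fold lower number from compound 2 to compound 4 (1.08 log units; beyond the scatter). Going by these compounds alone, all three earlier compounds end in a triple bond, so this is the first sign that the alkyne is not needed at this place for a lower number, and that a group with an aromatic ring is accepted there. Nothing available explains the size of this step.

Open, as far as these compounds go, is whether the step comes from the ring itself or from its chlorine, which a plain phenyl or a 4-fluorophenyl on the same chain would help to separate. Also open, from the compounds shown here alone, is whether the same change holds with a longer chain or on the core of compound 1.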